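The source may report more compounds than this note shows. Statements on the series, on what has been measured and on what is new or still open speak of the compounds shown alone.

Working notes on a small series sharing one core. In an ADME assay on DU-145 cells (Homo sapiens) for cytotoxicity, read by MTT assay, with a stated time of 72 h (a lower number here means a stronger inhibitor, a higher number a weaker inhibitor), compound 1 (`COc1ccc(C2=C(c3cc(OC)c(OC)c(OC)c3)C(=O)CC2O[SiH2]C(C)(C)C)cc1`) gives > 100 ug/mL as a limit of the assay, not a number. Compound 2 (`COc1ccc(C2=C(c3cc(OC)c(OC)c(OC)c3)C(=O)C(O)C2)cc1NC(=O)c1ccccc1`) gives > 100 ug/mL as a limit as well. Going by the values given here, compound 3 (`COc1ccc(C2=C(c3cc(OC)c(OC)c(OC)c3)C(=O)CC2O)cc1O`) gives 8 ug/mL as the only true number in the set. Among the compounds with values here, no measured step links compound 3 to the other two compounds.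

Compound 4 (`COc1ccc(C2=C(c3cc(OC)c(OC)c(OC)c3)C(=O)CC2O)cc1`), still unmeasured, has hydrogen in place of hydroxy on an aromatic carbon ortho to a methoxy group, so that 3-hydroxy-4-methoxyphenyl becomes 4-methoxyphenyl (hydrogen in place of hydroxy on an aromatic carbon). Within the data shown here, no measured pair in the set isolates this change, and the expectation rests on compound 3 at 8 ug/mL as its only anchor. A modest move toward a weaker inhibitor is expected, estimated as a 2.5-fold higher number from compound 3 to compound 4 (0.40 log units; beyond the scatter) in this assay with wide uncertainty. The expected value for compound 4 is 20 ug/mL (5 ug/mL to 80 ug/mL).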

Compound 4, half-maximal inhibitory concentration: 18.7 ug/mL
Beside the measured number, compound 4's estimate is 1.1-fold (0.03 log units) above it; measured number inside the range.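

In this assay, hydrogen in place of hydroxy on the aromatic carbon ortho to a methoxy group gives a 2.3-fold higher number from compound 3 to compound 4 (0.37 log units; beyond the scatter), so this hydroxy contributes a modest step and compound 4 still gives a true number without it. Going by these compounds alone, at the oxygen on a saturated carbon, a hydrogen atom in place of the silicon-bearing group gives an at least 5.3-fold lower number from compound 1 to compound 4 (0.72 log units; beyond the scatter), the first reading of a change at that oxygen. This step is a bound and not a measured size, set by a limit of the assay: the limit of > 100 ug/mL in this assay, at which 2 of the 4 values shown sit.

From the compounds shown here alone, what an amine or a fluorine would do on the same aromatic carbon stays open, so the hydroxy is compared only with hydrogen. Compound 2 differs from compound 4 in more than one place and gives no reading of either position.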